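Moving the Nitro Group from Compound 2 to Compound 3

This account rests on a few compounds, and the source may have more. Where it says the series, first, only, none or still open, it means among the compounds named here.

Compound 1, `COc1cccc(OC)c1OCCNCCOc1ccccc1OCc1cccc(Cl)c1`, gives 8.72 in a functional assay on thoracic aorta for antagonist activity at Alpha-1D adrenergic receptor (Rattus norvegicus); a higher number here means a more potent compound, by a factor of ten per unit of this negative logarithm, a lower number a less potent compound.
Compound 2, `COc1cccc(OC)c1OCCNCCOc1ccccc1OCc1ccccc1[N+](=O)[O-]`, gives 8.95.

Compound 2 holds the higher of the two measured numbers, but the step of a number 0.23 log units higher from compound 1 to compound 2 (within the scatter) lies within the usual scatter, so the two compounds cannot be ranked against each other. Compound 3, `COc1cccc(OC)c1OCCNCCOc1ccccc1OCc1cccc([N+](=O)[O-])c1`, is built from the same atoms as compound 2, joined differently: 3-nitrophenyl in place of 2-nitrophenyl on a saturated chain carbon bound to an oxygen on an aromatic ring.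

Among the compounds with values here, only one measured step exists, a number 0.23 log units higher from compound 1 to compound 2 (within the scatter), and it exchanges one group for another rather than shifting the same group to another position. It therefore gives no direct guidance on moving the nitro group, beyond showing that changes at this place have so far stayed within the scatter. The step from compound 2 to compound 3 is therefore expected to be small, a number 0.15 log units lower from compound 2 to compound 3 (within the scatter), with no clear direction. Compound 3 is estimated at 8.8, within a range from 8.3 to 9.3.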

Compound 3, negative logarithm of the antagonist equilibrium constant: 9.28
Estimate against measurement, compound 3: 0.48 log units below; low and high end bracket the measured number.
By their numbers in this assay, from the lowest: compounds 1 and 2 (each within the scatter of the next); then compound 3.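

Compounds 1 and 2 could not be told apart, but this position now gives a readable difference in this assay. With the same atoms, 3-nitrobenzyl in place of 2-nitrobenzyl gives a modest change (a number 0.33 log units higher from compound 2 to compound 3 (beyond the scatter)), so where the nitro group sits on the ring matters here, while nitro in place of chloro on an aromatic carbon also gives a modest change (a number 0.56 log units higher from compound 1 to compound 3 (beyond the scatter)). Nothing at hand gives a reason for either step.

The compounds shown leave open how 4-nitrobenzyl or plain benzyl would compare at this place. They also leave open whether another group on the ring, such as a nitrile or a methoxy, would match nitro in the 3-nitrobenzyl arrangement.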